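This account rests on a few compounds, and the source may have more. Where it says the series, first, only, none or still open, it means among the compounds named here.

Measured in a physicochemical assay for lipophilicity, using the shake flask method; a higher number here means a more lipophilic compound, a lower number a more polar compound:

- compound 1 `Cc1cc(O[C@@H](C)c2c(Cl)ccc(F)c2Cl)ccc1/C=C/C(=O)O`: 3.2
- compound 2 `C[C@H](Oc1ccc2ncc(-c3ccn(CCC(=O)O)n3)c(C3CC3)c2c1)c1c(Cl)cccc1Cl`: 2.7
- compound 3 `C[C@H](Oc1ccc2ncc(/C=C/c3nn[nH]n3)c(C(F)F)c2c1)c1c(Cl)cccc1Cl`: 3.3

Compound 1 stands within the scatter of compound 3, while compound 2 lies lower, beyond the scatter. The next compound to be measured is compound 4 `C[C@H](Oc1ccc(/C=C/C(=O)O)c(C2CC2)c1)c1c(Cl)ccc(F)c1Cl`. It differs from compound 1 by cyclopropyl in place of methyl on an aromatic carbon. Going by the values given here, no measured pair shows this change, so the expectation is rough: a modest rise in this assay, possibly not much beyond the scatter. The expected change is a number 0.40 log units higher from compound 1 to compound 4 (beyond the scatter). For compound 4 the estimate is 3.6, with an expected range from 3.2 to 4.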

Compound 4, distribution coefficient: 3.6
Compound 4: the middle estimate sits on the measured number at the digits printed; the measured number falls inside the stated range.
By their numbers in this assay, from the lowest: compound 2; then compounds 1, 3 and 4 (each within the scatter of the next, the first and the last beyond it).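

Among the compounds shown, only this pair differs in one place, so it gives a direct reading of a single change. In this assay, cyclopropyl in place of methyl on this aromatic carbon, ortho to the 2-carboxyethenyl group, gives a number 0.40 log units higher from compound 1 to compound 4 (beyond the scatter). Nothing available here explains this step. Going by these compounds, how an ethyl or a methoxy group at this place would compare remains open. So does whether the same change would give a similar step on another core.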